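This account rests on a few compounds, and the source may have more. Where it says the series, first, only, none or still open, it means among the compounds named here.

Compound 1 `COc1ccc(C(=O)/C=C/c2ccccc2)cc1N`: > 100000 nM
Compound 2 `COc1ccc(/C=C/C(=O)c2ccc(OC)c([N+](=O)[O-])c2)cc1`: > 100000 nM

Of the compounds shown here, two have been measured in a functional assay on B16 cells (Mus musculus) for cytotoxicity, read by MTT assay, with a stated time of 3 days; a higher number here means a weaker inhibitor, a lower number a stronger inhibitor. Compound 1 reaches only a limit of the assay, > 100000 nM. Compound 2 likewise gives only a limit, > 100000 nM. Where compound 2 stands is therefore not a number: it sits at the limit of > 100000 nM in this assay, at which 2 of the 2 values shown sit, together with the other measured compound, and nothing finer is known about it.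

Compound 3 `COc1ccc(/C=C/C(=O)c2ccc(OC)c(N)c2)cc1` is the unmeasured neighbour of compound 2 and differs from it in one place: amino in place of nitro on an aromatic carbon. Going by the values given here, no step between measured compounds has been resolved; both values are limits, so the size of this change cannot be read from the data. The account expects no step beyond the scatter. For compound 3 the expected step is a number no higher from compound 2 to compound 3 (the limit leaves the size open). Compound 3 is accordingly estimated at 100000 nM, within 30000 nM to 300000 nM, most likely reported again as a limit.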

Compound 3, half-maximal inhibitory concentration: 43000 nM
The estimate for compound 3 lay 2.3-fold (0.37 log units) above the measured number, within the range that was stated.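

In this assay, going by these compounds alone, compound 3 gives the only value of the three that is not a limit, so this position, ortho to a methoxy group, now shows a response to change: amino in place of nitro gives an at least 2.3-fold lower number from compound 2 to compound 3 (0.36 log units; beyond the scatter). Methoxy in place of hydrogen on an aromatic carbon also matters when the amino group is present, giving an at least 2.3-fold lower number from compound 1 to compound 3 (0.36 log units; beyond the scatter). Both steps are bounds and not exact sizes, as the far end of each is a limit of the assay: the limit of > 100000 nM in this assay, at which 2 of the 3 values shown sit.

The compounds shown leave open whether the amino group itself is needed here, or whether a hydroxyl group or an acetamide at this position would give a similar number. They also leave open how a dimethylamino group would compare with the amino group of compound 3.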